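The source may report more compounds than this note shows. Statements on the series, on what has been measured and on what is new or still open speak of the compounds shown alone.

The measured compounds and their values:

Compound 1, `CC(O)(CSc1ccc(Cl)cc1)c1nc(-c2ccccc2)no1`, in a functional assay on DU-145 cells (Homo sapiens) for cytotoxicity, read by MTT assay; a higher number here means a weaker inhibitor, a lower number a stronger inhibitor: 70700 nM
Compound 2, `CC(O)(CSc1ccc(F)cc1)c1nc(-c2ccccc2)no1`, in this assay: reported only as a limit, > 100000 nM
Compound 3, `CC(O)(CS(=O)(=O)c1ccc(Cl)cc1)c1nc(-c2ccc([N+](=O)[O-])c(C(F)(F)F)c2)no1`, in this assay: 91000 nM

Compound 2 differs from compound 1 by fluoro in place of chloro on an aromatic carbon. That change gave an at least 1.4-fold higher number from compound 1 to compound 2 (0.15 log units; that floor lies within the scatter); the step is bounded by the limit of > 100000 nM in this assay, at which 1 of the 3 values shown sits, so its true size is not known. Compound 3 differs from compound 1 in more than one place; how the two cores differ is not broken down here. Compound 3 and compound 1 lie within the scatter of each other.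

Compound 4, `CC(O)(CS(=O)(=O)c1ccc(F)cc1)c1nc(-c2ccc([N+](=O)[O-])c(C(F)(F)F)c2)no1`, is not yet measured. It differs from compound 3 by fluoro in place of chloro on an aromatic carbon, the same change as from compound 1 to compound 2, at the same kind of place. On the strength of the earlier step, compound 3 to compound 4 is expected to give a 1.4-fold higher number from compound 3 to compound 4 (0.15 log units; within the scatter), a step that cannot be sized well because the earlier one sits against (the limit of > 100000 nM in this assay, at which 1 of the 3 values shown sits). For compound 4 the estimated value in this assay is 130000 nM, expected to fall between 70000 nM and 300000 nM.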

Compound 4, half-maximal inhibitory concentration: > 100000 nM
Compound 4: a limit, no number; the forecaster's own chance of this, stated with the estimate: 65%; the middle value is on the limit's open side.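

In this assay, compound 4 is reported only as a limit, > 100000 nM. Fluoro in place of chloro on the core of compound 3 gives an at least 1.0-fold higher number from compound 3 to compound 4 (0.04 log units; that floor lies within the scatter), so on this second core, as on the first, the change ends at a limit and not at a measured number. This shows that nothing in the two steps speaks against carrying the change from one core to the other, but it does not show that the step keeps its size, since neither step has a known true size: the same change on two cores in this assay, an at least 1.4-fold higher number (0.15 log units; that floor lies within the scatter) from compound 1 to compound 2 and an at least 1.0-fold higher number (0.04 log units; that floor lies within the scatter) from compound 3 to compound 4; the limit leaves it open whether they differ.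

The compounds shown leave open how the series would read with other groups on that aromatic carbon, such as a methoxy group, an amine or a nitrile, none of which stands among them. They also leave open what the sulfonyl group contributes on its own, as compound 1 and compound 3 differ in more than one place.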